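The compounds below may be only part of what the source reports. "The series", "measured", "known", "first", "only" and "open" are said of these compounds alone.

Compound 1 `Cc1nc(N)sc1CCCNC(=N)NC(=O)CC(C)c1ccccc1` gives 49 nM in a functional assay on cardiac atrium for agonist activity at histamine H2 receptor (Cavia porcellus); a lower number here means that less compound is needed, a higher number that more compound is needed for the effect.
Compound 2 `Cc1nc(N)sc1CCCNC(=N)NC(=O)C[C@H](C)c1ccccc1` gives 39.8 nM in this assay.

Going by the values given here, compound 2 is one of only two measured compounds, and its single neighbour is compound 1; the step of a 1.2-fold lower number from compound 1 to compound 2 (0.09 log units; within the scatter) is within the scatter, so the two cannot be told apart on these numbers. All that separates them is the fact that one of compounds 1 and 2 is drawn with a defined configuration and the other without, at the place where they differ, and nothing further can be read from that.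

Compound 3 `Cc1nc(N)sc1CCCNC(=N)NC(=O)C[C@@H](C)C1CCCCC1` has not yet been measured. It differs from compound 2 by 1-cyclohexylethyl in place of 1-phenylethyl on a saturated chain carbon bound to a carbonyl carbon. Among the compounds with values here, no measured step bears on this change: the one step known, from compound 1 to compound 2, concerns only the drawing of a stereocentre and says nothing about exchanging an aromatic ring for a non-aromatic one. Without such a step, the expectation in this assay can rest only on the number of compound 2, 39.8 nM. The expected step of a 1.5-fold higher number from compound 2 to compound 3 (0.18 log units; within the scatter) is therefore set close to no change, with a wide range to allow for either direction. Compound 3 is thus estimated at 60 nM, with a range from 15 nM to 250 nM.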

Compound 3, half-maximal effective concentration: 57.5 nM
Compound 3: the middle estimate sits 1.0-fold (0.02 log units) above what was measured, and the stated range covers the measured number.
By their numbers in this assay, from the lowest: compounds 2, 1 and 3 (each within the scatter of the next).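

The step of a 1.4-fold higher number from compound 2 to compound 3 (0.16 log units; within the scatter) and the step of a 1.2-fold higher number from compound 1 to compound 3 (0.07 log units; within the scatter) in this assay both come from putting the non-aromatic ring of 1-cyclohexylethyl in place of the aromatic ring of 1-phenylethyl on a saturated chain carbon bound to a carbonyl carbon. The earlier compounds shown here differed at this place only in how a stereocentre was drawn; now the ring itself has been exchanged, and the three compounds still cannot be told apart, so in this small set an aromatic ring at this place is not needed for a number in this range. Nothing measured here explains why the two rings read alike.

Open, going by these compounds, is how much of the ring matters at all: a small isopropyl group without any ring, or a cyclohexyl ring carrying an amine or a carboxylic acid, might read quite differently. Also open, on these data alone, is whether a longer chain between the carbonyl and the ring would keep the number in the same range.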